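Swapping an Aryl Amide Group for a Saturated Chain

A few compounds are considered here, and "the series" means these few. Any claim that something is new, unique, unknown or untested is made for them only; others in the source may bear on it.

Compound 1 `Cc1ccc(NC(=O)c2cccc(/C=C3\CC(=O)N(c4ccccc4)C3=O)c2)cc1`: > 100000 nM
Compound 2 `Cc1ccc(N2C(=O)C/C(=C\c3cccc(C(=O)Nc4ccc(Cl)cc4)c3)C2=O)cc1`: > 100000 nM
Compound 3 `COc1cc(NC(=O)c2cccc(/C=C3\CC(=O)N(c4ccccc4)C3=O)c2)cc(OC)c1OC`: > 100000 nM

All three compounds were tested in an ADME assay on SW480 cells (Homo sapiens) for cytotoxicity, read by MTT assay, with a stated time of 72 h; a lower number here means a stronger inhibitor, a higher number a weaker inhibitor. For compound 1 the result is a limit of the assay rather than a number. The same holds for compound 2. The same holds for compound 3. So compound 1 stands exactly where the other two stand: at the limit of > 100000 nM in this assay, at which 3 of the 3 values shown sit, which means none of the three shows measurable cytotoxicity up to the highest concentration tested, and no ordering among them can be read from these results.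

Within the data shown here, compound 4 `O=C(NCC1CCCCC1)c1cccc(/C=C2\CC(=O)N(c3ccccc3)C2=O)c1` keeps the shared core of compound 1 and changes only one group: cyclohexylmethyl in place of 4-methylphenyl on an amide-type nitrogen. The difference is a move from an aromatic ring to a saturated ring of the same size, attached through one extra carbon.

Among the measured compounds shown here, since every measured compound sits at the limit, there is no measured step to lean on. The expectation for compound 4 is therefore that it behaves like compound 1, with the step of a number no higher from compound 1 to compound 4 (the limit leaves the size open) amounting to no change beyond the scatter. Compound 4 is expected to give about 100000 nM, within a range from 40000 nM to 300000 nM, and most likely again only a limit.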

Compound 4, half-maximal inhibitory concentration: > 100000 nM
Compound 4 ended at the assay's limit; the forecaster's own chance of this, stated with the estimate: 80%; the middle value sits exactly at the limit.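

Compound 4 gives > 100000 nM as a limit of the assay, not a number. The step from compound 1 to compound 4 therefore cannot be read, since all the compounds shown sit at the same limit: the limit of > 100000 nM in this assay, at which 4 of the 4 values shown sit.

The compounds shown leave open whether cyclohexylmethyl and 4-methylphenyl differ at all in their effect on these cells.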